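Replacing bromo with difluoromethoxy in compound 3

This account rests on a few compounds, and the source may have more. Where it says the series, first, only, none or still open, it means among the compounds named here.

In a physicochemical assay for solubility, read by HPLC, in phosphate buffer, with a stated time of 16 h, at pH 6.8 (a lower number here means a less soluble compound, a higher number a more soluble compound), compound 3 (`C[C@H](NC(=O)Cn1nnc2ccccc2c1=O)c1ccc(Br)cc1`) gives 900 nM as the lowest of three numbers. Compound 1 (`C[C@H](NC(=O)Cn1nnc2ccccc2c1=O)c1ccc(Cl)cc1`) gives 1900 nM and compound 2 (`Cc1ccc([C@H](C)NC(=O)Cn2nnc3ccccc3c2=O)cc1`) gives 12000 nM on the same scale. Compound 4 (`C[C@H](NC(=O)Cn1nnc2ccccc2c1=O)c1ccc(OC(F)F)cc1`) carries difluoromethoxy in place of bromo on an aromatic carbon. Swaps at this same place are the only guide: chloro to bromo gave a 2.1-fold lower number from compound 1 to compound 3 (0.32 log units; beyond the scatter) and was modest, while methyl to bromo gave a 13-fold lower number from compound 2 to compound 3 (1.12 log units; beyond the scatter) and was large. Neither swap involves difluoromethoxy, so the guide is loose. A modest rise is expected in this assay from the low end of the numbers (a 2.8-fold higher number from compound 3 to compound 4 (0.44 log units; beyond the scatter)). For compound 4 the estimate is 2500 nM with an expected range from 900 nM to 8000 nM for this reading.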

Compound 4, solubility: 2400 nM
Compound 4: middle estimate off by 1.0-fold (0.02 log units), on the high side; measured number inside the range.
By their numbers in this assay, from the lowest: compound 3; then compounds 1 and 4 (each within the scatter of the next); then compound 2.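

In this assay this position now holds a group with more heavy atoms than bromo, and the swap gives a 2.7-fold higher number from compound 3 to compound 4 (0.43 log units; beyond the scatter). The step of a 1.3-fold higher number from compound 1 to compound 4 (0.10 log units; within the scatter) stays within the scatter, so difluoromethoxy and chloro cannot be told apart here, while a 5.0-fold lower number from compound 2 to compound 4 (0.70 log units; beyond the scatter) leaves methyl with the highest number of the four. No measurement here gives a reason for these steps. The compounds shown leave open how an amine or a carboxylic acid would read at this position. They also leave open whether these steps would hold on another core.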